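A Chloro Added to the Aryl Urea of Compound 3

A few compounds are considered here, and "the series" means these few. Any claim that something is new, unique, unknown or untested is made for them only; others in the source may bear on it.

Compound 1 `COc1cc(-c2nn(-c3cccc(NC(=O)c4cccc(C(F)(F)F)c4)c3)cc2-c2ccncc2)ccc1Cl`: in a functional assay on SNB-19 cells (Homo sapiens) for inhibition, read by sulforhodamine B assay, with a stated time of 48 h (a lower number here means a stronger inhibitor of growth, a higher number a weaker inhibitor of growth), compound 1 gives > 50000 nM, a limit of the assay.
Compound 2 `COc1cc(-c2nn(-c3cccc(NC(=O)Nc4ccc(Cl)c(Cl)c4)c3)cc2-c2ccncc2)ccc1Cl`: in this assay compound 2 gives > 50000 nM, also a limit.
Compound 3 `COc1cc(-c2nn(-c3cccc(NC(=O)Nc4cccc(C(F)(F)F)c4)c3)cc2-c2ccncc2)ccc1Cl`: in this assay compound 3 gives 4000 nM.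

Among the measured compounds shown here, compound 3 holds the only number in this assay; the other two values sit at the limit of > 50000 nM in this assay, at which 2 of the 3 values shown sit. Compound 4 `COc1cc(-c2nn(-c3cccc(NC(=O)Nc4ccc(Cl)c(C(F)(F)F)c4)c3)cc2-c2ccncc2)ccc1Cl` differs from compound 3 by chloro in place of hydrogen on an aromatic carbon. The steps measured so far are an at least 12-fold lower number from compound 1 to compound 3 (1.09 log units; beyond the scatter) and an at least 12-fold lower number from compound 2 to compound 3 (1.09 log units; beyond the scatter), while a step that the two limits leave unreadable from compound 1 to compound 2. The second of these shows that swapping one trisubstituted aryl urea for another can move the number by a large amount, and in the present step a chlorine is added rather than exchanged, so the outcome is open. Compound 4 is expected near 3000 nM, between 700 nM and 20000 nM, a step of a 1.3-fold lower number from compound 3 to compound 4 (0.12 log units; within the scatter).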

Compound 4, concentration for total growth inhibition: 9240 nM
The estimate for compound 4 lay 3.1-fold (0.49 log units) below the measured number; the measured number falls inside the stated range.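

In this assay, chloro on the aromatic carbon ortho to a trifluoromethyl group and para to a large group is tolerated but weakens growth inhibition, with a 2.3-fold higher number from compound 3 to compound 4 (0.36 log units; beyond the scatter). Trifluoromethyl in place of chloro on this ring still gives a stronger inhibitor, with an at least 5.4-fold lower number from compound 2 to compound 4 (0.73 log units; beyond the scatter), and the aryl urea of compound 4 retains its advantage over the amide, with an at least 5.4-fold lower number from compound 1 to compound 4 (0.73 log units; beyond the scatter). These last two steps give only bounds, as compound 1 and compound 2 each stand at a limit: the limit of > 50000 nM in this assay, at which 2 of the 4 values shown sit.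

On these data alone, whether fluoro, methoxy or an amine at this position would behave like chloro remains open. So does the true size of those two bounded steps.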